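Notes on the step from compound 2 to compound 3

The source may hold more compounds than are shown below. What is called first, only, known or untested is meant among the compounds shown, and "the series" means these compounds.

- compound 1 `CC(=O)Cn1nc(-c2cccnc2)c2ccccc2c1=O`: 40700 nM
- compound 2 `CCOC(=O)CCCn1nc(-c2cccnc2)c2ccccc2c1=O`: 10000 nM

Among the compounds with values here, in a functional assay (trachea) with Cavia porcellus as the target (on this read-out higher numbers stand for weaker inhibition and lower numbers for stronger inhibition), compound 2 has the lower of the two numbers, 10000 nM, and the only comparison is compound 1 at 40700 nM. Compound 3 `O=C(O)Cn1nc(-c2cccnc2)c2ccccc2c1=O` has not yet been measured. The change is carboxy in place of 2-(ethoxycarbonyl)ethyl on a saturated chain carbon bound to an aromatic nitrogen. Within the data shown here, one measured step bears on it, at the same place: a 4.1-fold lower number from compound 1 to compound 2 (0.61 log units; beyond the scatter), modest and beyond the scatter. That step brought in the group that now leaves, so a step of similar modest size towards a higher number is expected in this assay. Among the measured compounds shown here, no measured compound carries carboxy, so this direction remains tentative. The expected step is a 2.8-fold higher number from compound 2 to compound 3 (0.45 log units; beyond the scatter). For compound 3 the estimated value is 28000 nM, with an expected range of 9000 nM to 90000 nM.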

Compound 3, half-maximal inhibitory concentration: > 100000 nM
Compound 3 ended at the assay's limit (the forecaster's own chance of this, stated with the estimate: 15%); middle value at least 3.5-fold (0.55 log units) from the limit.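

In this assay compound 3 gives > 100000 nM as a limit of the assay and not a number: the limit of > 100000 nM in this assay, at which 1 of the 3 values shown sits.

Carboxy moves the number up from both earlier compounds, with an at least 10-fold higher number from compound 2 to compound 3 (1.00 log units; beyond the scatter) for the change from 2-(ethoxycarbonyl)ethyl and an at least 2.4-fold higher number from compound 1 to compound 3 (0.39 log units; beyond the scatter) for hydroxy in place of methyl on a carbonyl carbon. The earlier pair showed only a downward step at this position, so the series now has a change here that goes the other way, and compound 2 stays lowest of the three. Only a lower bound is fixed for the size of either step.

Against compound 2, compound 3 differs in both chain length and end group, so the two effects remain unseparated. A longer chain ending in a carboxylic acid, or a short chain ending in an amine, would show whether the higher number belongs to carboxy itself.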